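Removing a Methoxy Group: What to Expect for Compound 4

The source may hold more compounds than are shown below. What is called first, only, known or untested is meant among the compounds shown, and "the series" means these compounds.

Measured so far in a functional assay on U-87MG ATCC cells for antiproliferative activity against U-87 MG (Homo sapiens), read by MTT assay, with a stated time of 48 h, tested at 5 uM; on this read-out higher numbers stand for a weaker effect at the one concentration tested and lower numbers for a stronger effect:
- compound 1 `COc1ccc(-c2nc(C)c(C(=O)CSc3nc(N)c(C#N)c(-c4ccc(Cl)cc4)n3)s2)cc1` gives 51.4%
- compound 2 `COc1ccc(-c2nc(C)c(C(=O)CSc3nc(-c4cccc(OC)c4)c(C#N)c(=O)[nH]3)s2)cc1` gives 71.3%
- compound 3 `COc1ccc(-c2nc(C)c(C(=O)CSc3nc(-c4ccc(OC)c(OC)c4)c(C#N)c(=O)[nH]3)s2)cc1` gives 81.2%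

Compound 4 `Cc1nc(-c2ccccc2)sc1C(=O)CSc1nc(N)c(C#N)c(-c2ccc(Cl)cc2)n1` has not yet been measured in this assay. It differs from compound 1 in one place: hydrogen in place of methoxy on an aromatic carbon. The same kind of change has already been measured once, from compound 3 to compound 2: hydrogen in place of methoxy on an aromatic carbon. That step was a number 9.9 percentage points lower from compound 3 to compound 2 (within the scatter). The two places are not identical, though: in compound 3 the leaving methoxy sits ortho to a methoxy group, while in compound 1 no such neighbouring group is present, so this is the same kind of change rather than the same change. How the core of compound 1 differs from the core of compound 3 is not broken down here.

For the measured compounds named here, since the one measured example of this change, a number 9.9 percentage points lower from compound 3 to compound 2 (within the scatter), lies within the scatter, the step from compound 1 to compound 4 is expected to be small as well, a number 1.6 percentage points higher from compound 1 to compound 4 (within the scatter). Compound 4 is therefore estimated at 53% in this assay, between 38% and 68%.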

Compound 4, a percentage reported as activity, at one concentration (the size of the read-out at that concentration, not a potency): 62.9%
Estimate against measurement, compound 4: 9.9 percentage points below, within the range that was stated.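

In this assay, turning 4-methoxyphenyl into phenyl gives a number 11.5 percentage points higher from compound 1 to compound 4 (beyond the scatter), a modest loss of effect at the one concentration tested. The same kind of change therefore did not carry over unchanged from one core to the other: the same change on two cores in this assay, a number 9.9 percentage points lower (within the scatter) from compound 3 to compound 2 and a number 11.5 percentage points higher (beyond the scatter) from compound 1 to compound 4, 21.4 percentage points apart, beyond the scatter of two such steps. This rests on a single pair of steps, and the two pairs differ both in their cores and in where the methoxy group sits, so it shows that the result of this change cannot simply be copied across the series, but not which of those differences is responsible or what the change would do on a further core.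

The compounds shown leave open how a hydroxyl group, a carboxylic acid or a longer chain such as ethoxy would compare with methoxy and hydrogen in this place on the core of compound 1. They also leave open whether the step seen at this single concentration would hold at other concentrations.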